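The source may hold more compounds than are shown below. What is called first, only, known or untested is meant among the compounds shown, and "the series" means these compounds.

Working notes on the series. In a functional assay on MCF7 cells (Homo sapiens) for antiproliferative activity, read by MTT assay, with a stated time of 48 h (on this read-out lower numbers stand for stronger inhibition and higher numbers for weaker inhibition), compound 2 (`O=C(/C=C/c1ccc(C(F)(F)F)cc1)Nc1nnc(-c2ccccc2)s1`) gives 1.52 ug/mL, within the scatter of both compound 1 (`COc1ccc(-c2nnc(NC(=O)/C=C/c3ccc(F)cc3)s2)cc1`) at 0.85 ug/mL and compound 3 (`COc1ccc(/C=C/C(=O)Nc2nnc(-c3ccccc3)s2)cc1`) at 0.83 ug/mL. Compound 4 (`COc1ccc(-c2nnc(NC(=O)/C=C/c3ccc(C(F)(F)F)cc3)s2)cc1`) follows from compound 2 by one change: methoxy in place of hydrogen on an aromatic carbon. For the measured compounds named here, no measured step covers this change directly. The nearest evidence is a 1.8-fold lower number from compound 2 to compound 3 (0.26 log units; within the scatter), methoxy in place of trifluoromethyl at another place, and that step stays within the scatter. No step beyond the scatter is therefore expected in this assay. The estimated change is a 1.3-fold lower number from compound 2 to compound 4 (0.10 log units; within the scatter). Compound 4 is expected at 1.2 ug/mL, with an estimated range of 0.55 ug/mL to 2.6 ug/mL.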

Compound 4, half-maximal inhibitory concentration: 0.79 ug/mL
Compound 4: the middle estimate sits 1.5-fold (0.18 log units) above what was measured; the range from low to high includes it.
By their numbers in this assay, from the lowest: compounds 4, 3, 1 and 2 (each within the scatter of the next).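

In this assay, for the compounds shown here, the first direct reading of phenyl to 4-methoxyphenyl at this position gives a 1.9-fold lower number from compound 2 to compound 4 (0.28 log units; within the scatter) and so stays within the scatter. With the 4-methoxyphenyl group held constant, the change at the other end of the molecule gives a 1.1-fold lower number from compound 1 to compound 4 (0.03 log units; within the scatter) and leaves fluoro and trifluoromethyl indistinguishable in this pair. No supporting data bear on either step. From the compounds shown here alone, whether an amine or a carboxylic acid at the methoxy position would give a step beyond the scatter remains open, as does the result of a longer chain there.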